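Swapping 2-Carboxyethyl for 2-(Cyclopropylcarbamoyl)ethenyl on the Shared Core

The source may report more compounds than this note shows. Statements on the series, on what has been measured and on what is new or still open speak of the compounds shown alone.

Of the compounds shown here, two on a shared core have been measured in a functional assay on A549 cells (Homo sapiens) for inhibition, read by sulforhodamine B assay, with a stated time of 72 h; on this read-out higher numbers stand for weaker inhibition of growth and lower numbers for stronger inhibition of growth. Compound 1 `CCOC(=O)/C=C/c1ccncc1-c1ccc2[nH]ccc2c1` gives 7440 nM in this assay. Compound 2 `O=C(O)CCc1ccncc1-c1ccc2ccccc2c1` is the closer relative of the unmeasured compound. In this assay compound 2 gives > 10000 nM, which is a limit of the assay and not a number. Compound 2 therefore stands at the limit of > 10000 nM in this assay, at which 1 of the 2 values shown sits, the weak end of what has been seen, while compound 1 gives a measurable number. For the measured compounds named here, no pair of measured compounds differs in only one place, so the two values can only be set side by side.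

Compound 3 `O=C(/C=C/c1ccncc1-c1ccc2ccccc2c1)NC1CC1` differs from compound 2 in one place: 2-(cyclopropylcarbamoyl)ethenyl in place of 2-carboxyethyl on an aromatic carbon The count of hydrogen-bond donors and acceptors is unchanged, while a three-membered ring of carbon and a second double bond outside aromatic rings enter. Starting from a value at the limit, a step can only go toward stronger inhibition or remain at the limit. Compound 3 is expected to give 5000 nM, between 1500 nM and 20000 nM. The expected step of an at least 2.0-fold lower number from compound 2 to compound 3 (0.30 log units; that floor lies within the scatter) would exceed the usual scatter, though the assay may again report only a limit.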

Compound 3, concentration for 50% growth inhibition: 5840 nM
Compound 3: middle estimate off by 1.2-fold (0.07 log units), on the low side; the measured number falls inside the stated range.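

In this assay, the position opposite the ring nitrogen now gives a measurable result: with 2-(cyclopropylcarbamoyl)ethenyl at this position, compound 3 gives 5840 nM. The change therefore moves the value off the limit and can be read as an at least 1.7-fold lower number from compound 2 to compound 3 (0.23 log units; that floor lies within the scatter), which shows that this position tolerates the larger group without loss of the read-out, although the change in growth inhibition cannot be called firm. The step can be stated only as a floor, and its true size stays unknown, because compound 2 stands at a limit of the assay: the limit of > 10000 nM in this assay, at which 1 of the 3 values shown sits.

The compounds shown leave open which part of the new group matters, as the three-membered ring of carbon and the second double bond outside aromatic rings enter together in this single step. Also open, going by these compounds, is whether a carboxylic acid on the unsaturated chain, or an amine or a longer chain in place of the cyclopropyl group, would give a lower or a higher number at this position in this assay.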